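From 3-hydroxyphenyl to 4-methylphenyl in a cytotoxicity series

A few compounds are considered here, and "the series" means these few. Any claim that something is new, unique, unknown or untested is made for them only; others in the source may bear on it.

Within the data shown here, in a functional assay on U2OS cells (Homo sapiens) for cytotoxicity, read by MTT assay, with a stated time of 48 h (on this read-out higher numbers stand for weaker inhibition and lower numbers for stronger inhibition), compound 2 (`Oc1cccc(Nc2nc(-c3cccc(F)c3)nc3ccc(F)cc23)c1`) gives 33300 nM, the only actual number so far in this small set. Compound 1 (`Fc1cccc(-c2nc(Nc3ccc(Br)cc3)c3cc(F)ccc3n2)c1`) reads > 50000 nM, which is a limit of the assay and not a number. Among the measured compounds shown here, the one measured step shows an at least 1.5-fold lower number from compound 1 to compound 2 (0.17 log units; that floor lies within the scatter) and puts 3-hydroxyphenyl in place of 4-bromophenyl on a nitrogen on an aromatic ring.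

Compound 3 (`Cc1ccc(Nc2nc(-c3cccc(F)c3)nc3ccc(F)cc23)cc1`) keeps the shared core and carries 4-methylphenyl in place of 3-hydroxyphenyl at that nitrogen: 4-methylphenyl in place of 3-hydroxyphenyl on a nitrogen on an aromatic ring. For the measured compounds named here, the measured step is the only guide to this change, and it comes from a single pair with a limit at one end. Its floor stays within the scatter, so no step beyond the scatter is expected in this assay, with any drift more likely toward higher numbers. The expected change is a 1.3-fold higher number from compound 2 to compound 3 (0.10 log units; within the scatter). For compound 3 the estimated value is 42000 nM, with an expected range from 18000 nM to 90000 nM.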

Compound 3, half-maximal inhibitory concentration: > 50000 nM
Compound 3 was reported as a limit; the forecaster's own chance of this, stated with the estimate: 45%; middle value at least 1.1-fold (0.07 log units) away from the limit.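

Replacing 3-hydroxyphenyl with 4-methylphenyl at this nitrogen gives an at least 1.5-fold higher number from compound 2 to compound 3 (0.17 log units; that floor lies within the scatter). This shows that a group with no hydrogen-bond donor or acceptor at this position does not bring a reading below the limit in this assay, although the floor of the step does not establish a real loss. The step between compound 1 and compound 3, methyl in place of bromo on an aromatic carbon, cannot be read, and 3-hydroxyphenyl alone gives an actual number at this position, with no separation beyond the scatter from either limit: the limit of > 50000 nM in this assay, at which 2 of the 3 values shown sit.

Going by these compounds, how a 3-methylphenyl or a 4-hydroxyphenyl group would read at this nitrogen remains open, and with it whether the hydroxyl itself or its place on the ring matters for the number of compound 2. A 3-aminophenyl group, with an amine in place of the hydroxyl, would also leave open whether any reading at this position can fall clearly below that of compound 2.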